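The source may hold more compounds than are shown below. What is called first, only, known or untested is meant among the compounds shown, and "the series" means these compounds.

In a functional assay on SK-OV-3 cells (Homo sapiens) for inhibition, read by sulforhodamine B assay, with a stated time of 48 h (a lower number here means a stronger inhibitor, a higher number a weaker inhibitor), compound 1 (`CCCN(c1ccc(OC)cc1)c1ncnc2occ(C)c12`) gives 40.3 nM, compound 2 (`CCc1ccc(N(C)c2ncnc3occ(C)c23)cc1`) gives 156 nM and compound 3 (`CCCCN(c1ccc(OC)cc1)c1ncnc2occ(C)c12`) gives 148 nM. Compound 3 therefore sits within the scatter of compound 2, and both lie clearly on the high side of compound 1.

Compound 4 (`COc1ccc(N(C)c2ncnc3occ(C)c23)cc1`) differs from compound 3 by hydrogen in place of propyl on a saturated chain carbon bound to a nitrogen on an aromatic ring, or butyl to methyl when cut one bond further out.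

Among the compounds with values here, one measured step bears on this chain: a 3.7-fold higher number from compound 1 to compound 3 (0.56 log units; beyond the scatter), a modest change beyond the scatter. Shortening the chain runs opposite to that step, so a lower number is expected in this assay, of similar or somewhat larger size. Within the data shown here, this rests on a single step, and no measured step links compound 4 to compound 2.

The estimated step is a 4.9-fold lower number from compound 3 to compound 4 (0.69 log units; beyond the scatter). For compound 4 the estimated value is 30 nM, with an expected range of 10 nM to 90 nM.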

Compound 4, half-maximal inhibitory concentration: 7.7 nM
Compound 4: middle estimate off by 3.9-fold (0.59 log units), on the high side; measured number outside the range, below it.
By their numbers in this assay, from the lowest: compound 4; then compound 1; then compounds 3 and 2 (each within the scatter of the next).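

On the saturated chain carbon bound to a nitrogen on an aromatic ring, the numbers in this assay fall as the chain shortens from butyl through propyl to methyl, with a 19-fold lower number from compound 3 to compound 4 (1.28 log units; beyond the scatter) and a 5.2-fold lower number from compound 1 to compound 4 (0.72 log units; beyond the scatter) extending the rise seen in a 3.7-fold higher number from compound 1 to compound 3 (0.56 log units; beyond the scatter); none of these three compounds goes against this order. With methyl on that nitrogen in both compounds, the aromatic substituent also carries a large effect, as methoxy in place of ethyl on an aromatic carbon gives a 20-fold lower number from compound 2 to compound 4 (1.31 log units; beyond the scatter). No supporting measurement bears on why either change lowers the number.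

Still open, from the compounds shown here alone, is whether the order holds for an ethyl chain or whether hydrogen on that nitrogen lowers the number further. A chain ending in an amine or a hydroxyl group, and the pairing of ethyl on the aromatic carbon with propyl or butyl on the nitrogen, also remain untested in the compounds shown.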